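A few compounds are considered here, and "the series" means these few. Any claim that something is new, unique, unknown or untested is made for them only; others in the source may bear on it.

Measured compounds:
- compound 1, `COc1cc(C(=O)c2ccc3c(ccn3S(=O)(=O)c3ccc(/C=C/C(=O)NO)cc3)c2)cc(OC)c1OC`: 5340 nM
- compound 2, `COc1ccc(C(=O)c2ccc3c(ccn3S(=O)(=O)c3ccc(/C=C/C(=O)NO)cc3)c2)cc1`: 10000 nM
- compound 3, `O=C(NO)c1ccc(Cn2ccc3cc(C(=O)c4ccc(Cl)cc4)ccc32)cc1`: 1060 nM

In an assay on isolated protein for inhibition of histone deacetylase 8 (Homo sapiens) (a higher number here means a weaker inhibitor, a lower number a stronger inhibitor), compound 1 gives the second highest of the three numbers. Compound 2 sits nearest, and the step of a 1.9-fold higher number from compound 1 to compound 2 (0.27 log units; within the scatter) stays within the scatter. Compound 3 lies furthest away, with a number clearly lower than that of compound 1. The unmeasured compound 4, `COc1cc(C(=O)c2ccc3c(ccn3S(=O)(=O)c3cccc(/C=C/C(=O)NO)c3)c2)cc(OC)c1OC`, differs from compound 1 only in the change (3-(2-(hydroxycarbamoyl)ethenyl)phenyl in place of 4-(2-(hydroxycarbamoyl)ethenyl)phenyl on a sulfonyl sulfur). For the measured compounds named here, no measured step touches this part of the molecule: the single step on record, a 1.9-fold higher number from compound 1 to compound 2 (0.27 log units; within the scatter), alters a different group, so it offers no guide to the size or direction of the change at hand. The step of a 1.3-fold higher number from compound 1 to compound 4 (0.12 log units; within the scatter) is therefore expected to stay within the scatter. Compound 4 is estimated at 7000 nM, within a range from 2500 nM to 20000 nM.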

Compound 4, half-maximal inhibitory concentration: 1260 nM
Compound 4: the middle estimate sits 5.6-fold (0.74 log units) above what was measured; measured number outside the range, below it.
By their numbers in this assay, from the lowest: compounds 3 and 4 (each within the scatter of the next); then compounds 1 and 2 (each within the scatter of the next).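

Swapping in 3-(2-(hydroxycarbamoyl)ethenyl)phenyl for 4-(2-(hydroxycarbamoyl)ethenyl)phenyl on the sulfonyl sulfur gives a 4.2-fold lower number from compound 1 to compound 4 (0.63 log units; beyond the scatter) in this assay, with the same atoms simply joined differently. At this position, then, the attachment pattern of the ring alone changes the result, which the earlier step, made at a different group, could not show. No measurement here explains the difference.

On these data alone, it remains open whether the same swap would have a similar effect in compound 2, which carries the 4-methoxyphenyl group. As far as these compounds go, it is also open whether a carboxylic acid could replace the hydroxycarbamoyl group on this repositioned chain.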